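Swapping an Acid for a Dimethylamino Group: Tolerability Outlook

A few compounds are considered here, and "the series" means these few. Any claim that something is new, unique, unknown or untested is made for them only; others in the source may bear on it.

Of the compounds shown here, two sharing one core have been tested in a toxicity assay on MDCK cells (Canis lupus familiaris) for cytotoxicity, read by crystal violet staining, with a stated time of 48 h; a higher number here means that more compound is tolerated, a lower number that less compound is tolerated. Compound 1, `CCc1ccc2[nH]c(=O)c(CN(Cc3ccc(F)cc3)Cc3ccc(C(C)(C)C)cc3)cc2c1`, gave a reading that is a limit of the assay rather than a number: in this assay compound 1 shows > 33000 nM. Compound 2, `Cc1ccc2[nH]c(=O)c(CN(Cc3ccc(OCC(=O)O)cc3)Cc3ccc(C(C)(C)C)cc3)cc2c1`, likewise reached only a limit. In this assay compound 2 shows > 10000 nM. Within the data shown here, compound 2 therefore stands at a limit, and the single other reading is a limit too, so neither value says how far the tolerated concentration really extends. Compound 3, `Cc1ccc2[nH]c(=O)c(CN(Cc3ccc(N(C)C)cc3)Cc3ccc(C(C)(C)C)cc3)cc2c1`, is the next compound. It differs from compound 2 in one place: dimethylamino in place of carboxymethoxy on an aromatic carbon. Among the measured compounds shown here, no measured pair differing in one place exists here, so the size of the step can only be estimated. The reading of compound 2 sits at a limit (the limit of > 10000 nM in this assay, at which 1 of the 2 values shown sits). The reading of compound 1 sits at a limit (the limit of > 33000 nM in this assay, at which 1 of the 2 values shown sits). Both point to little cytotoxicity, and the change is expected to shift tolerability little, if at all, beyond the scatter. The expected step in this assay is a step that the limit leaves unreadable from compound 2 to compound 3. Compound 3 is estimated at 20000 nM, within 5000 nM to 60000 nM.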

Compound 3, half-maximal cytotoxic concentration: > 5000 nM
Compound 3 gave a limit, no number (the forecaster's own chance of this, stated with the estimate: 70%); the middle value lies beyond the limit too.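

Among these compounds, compound 2 and compound 3 both gave only a limit of the assay in this assay, and no step between them can be read. The compounds shown leave open what concentration of any of them is half-maximally cytotoxic, and whether dimethylamino in place of carboxymethoxy changes tolerability at all.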